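This account rests on a few compounds, and the source may have more. Where it says the series, first, only, none or still open, it means among the compounds named here.

Compound 1 `COc1cc(NC(C)CCCNC(=O)Nc2cccc(F)c2)c2ncccc2c1` is the weaker of the two compounds measured in a functional assay on SW-620 cells (Homo sapiens) for inhibition, read by MTT assay, with a stated time of 72 h; a higher number here means a weaker inhibitor, a lower number a stronger inhibitor: compound 1 gives 27000 nM, the highest number of the pair. Compound 2 `COc1cc(NC(C)CCCNC(=O)NNC(=O)Nc2ccc(C(F)(F)F)cc2)c2ncccc2c1` gives 12000 nM in this assay, a lower number that sits beyond the usual scatter. Compound 3 `COc1cc(NC(C)CCCNC(=O)NNC(=O)Nc2cccc(Cl)c2)c2ncccc2c1` has not yet been measured. Compared with compound 1 it carries ((3-chlorophenyl)carbamoyl)amino in place of 3-fluorophenyl on an amide-type nitrogen. Because compound 2, which gives 12000 nM, already carries a carbamoylamino linker of this kind, a modest lowering of the number is expected, with the step of a 1.9-fold lower number from compound 1 to compound 3 (0.29 log units; within the scatter) estimated to lie beyond the scatter. For compound 3 the expected value is 14000 nM, most likely between 6000 nM and 32000 nM.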

Compound 3, half-maximal inhibitory concentration: 25000 nM
The estimate for compound 3 lay 1.8-fold (0.25 log units) below the measured number; measured number inside the range.
By their numbers in this assay, from the lowest: compound 2; then compounds 3 and 1 (each within the scatter of the next).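

In this assay, putting ((3-chlorophenyl)carbamoyl)amino in place of 3-fluorophenyl on the amide-type nitrogen gives a 1.1-fold lower number from compound 1 to compound 3 (0.03 log units; within the scatter), so this larger change leaves compounds 1 and 3 indistinguishable. With the carbamoylamino linker kept, 3-chlorophenyl in place of 4-(trifluoromethyl)phenyl gives a 2.1-fold higher number from compound 2 to compound 3 (0.32 log units; beyond the scatter), so the choice of aryl group on that linker shifts the number modestly. Nothing shown here explains either step.

Still open, on these data alone, is whether 3-fluorophenyl on the same linker would read like compound 3. As far as these compounds go, how an amine or a carboxylic acid on the phenyl ring, or a longer chain in the linker, would read also remains unknown.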